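The compounds below may be only part of what the source reports. "The series", "measured", "known", "first", "only" and "open" are said of these compounds alone.

Measured in an ADME assay on BJ cells (Homo sapiens), read by MTT assay, with a stated time of 72 h; a lower number here means a stronger inhibitor, a higher number a weaker inhibitor:
Compound 1 `C#Cc1cn([C@@H]2O[C@H](CO)[C@@H](O)[C@H]2O)c2ncnc(NC)c12`: 86000 nM
Compound 2 `Cc1nc(N)c2c(-c3ccoc3)cn([C@@H]3O[C@H](CO)[C@@H](O)[C@H]3O)c2n1`: > 100000 nM
Compound 3 `COc1nc(N)nc2c1c(-c1ccoc1)cn2[C@@H]1O[C@H](CO)[C@@H](O)[C@H]1O`: > 100000 nM

Compound 2 reads > 100000 nM in this assay, and this is a limit of the assay, not a number. Compound 3 reads > 100000 nM, which is also a limit. Compound 2 therefore stands at the limit of > 100000 nM in this assay, at which 2 of the 3 values shown sit. Only compound 1 gives a true number, 86000 nM.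

Compound 4 `Cc1nc(N)c2c(I)cn([C@@H]3O[C@H](CO)[C@@H](O)[C@H]3O)c2n1` keeps the core of compound 2 and changes one group: iodo in place of furan-3-yl on an aromatic carbon. This puts iodo in place of furan-3-yl on an aromatic carbon. Within the data shown here, no pair of measured compounds shows what such a swap does in this assay, so the expectation rests on very little. Compound 1 carries neither group and gives 86000 nM, which suggests that a similarly high number is plausible for this family. The expected change a number no higher from compound 2 to compound 4 (the limit leaves the size open) is none beyond the usual scatter, and another limit is quite likely. Compound 4 is estimated at 100000 nM, with an expected range of 40000 nM to 200000 nM.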

Compound 4, half-maximal inhibitory concentration: 24600 nM
Compound 4: middle estimate off by 4.1-fold (0.61 log units), on the high side; measured number outside the range, below it.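

In this assay, iodo in place of furan-3-yl on this aromatic carbon gives an at least 4.0-fold lower number from compound 2 to compound 4 (0.60 log units; beyond the scatter), so the group at this position can change the read-out. Compound 4 gives a true number, 24600 nM, and so offers a measured starting point for comparing other groups at this position. The size of the step remains only a lower bound because compound 2 reads as a limit of the assay, not a number: the limit of > 100000 nM in this assay, at which 2 of the 4 values shown sit.

A single swap cannot tell whether the lower number comes from the iodo group itself or from the loss of the furan-3-yl ring. Chloro, bromo or an amine at the same position could help separate these two readings, and the same swap on the core of compound 3 could show whether the step carries over.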